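Losing the lactam group from compound 3

The source may report more compounds than this note shows. Statements on the series, on what has been measured and on what is new or still open speak of the compounds shown alone.

Compounds, measured in a functional assay on HeLa cells (Homo sapiens) for inhibition, read by sulforhodamine B assay, with a stated time of 74 h; a lower number here means a stronger inhibitor, a higher number a weaker inhibitor:
- Compound 1 `O=C1C=CC2(C=C1)OCC(=O)N2S(=O)(=O)c1ccccc1`: > 10000 nM (a limit of the assay)
- Compound 2 `O=C1C=CC2(C=C1)OCC(=O)N2S(=O)(=O)c1ccc(Cl)cc1`: > 10000 nM (a limit of the assay)
- Compound 3 `O=C1C=CC2(C=C1)OCC(=O)N2S(=O)(=O)c1ccc(N2CCCC2=O)cc1`: 880 nM
- Compound 4 `O=C1C=CC2(C=C1)OCC(=O)N2S(=O)(=O)c1ccc(OC(F)(F)F)cc1`: not yet measured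

Among the compounds with values here, compound 3 gives the only true number in the set, 880 nM. The other two results are not numbers but limits: the limit of > 10000 nM in this assay, at which 2 of the 3 values shown sit.

Compound 4 carries trifluoromethoxy in place of 2-oxopyrrolidin-1-yl on an aromatic carbon. Two large measured steps bear on this change, both with 2-oxopyrrolidin-1-yl entering: an at least 11-fold lower number from compound 1 to compound 3 (1.05 log units; beyond the scatter) and an at least 11-fold lower number from compound 2 to compound 3 (1.05 log units; beyond the scatter). The chloro-for-hydrogen change is less informative, being a step that the two limits leave unreadable from compound 1 to compound 2.

Compound 4 gives up the group that entered in an at least 11-fold lower number from compound 2 to compound 3 (1.05 log units; beyond the scatter), so a large move to a higher number is expected in this assay. The expected change is an 8.0-fold higher number from compound 3 to compound 4 (0.90 log units; beyond the scatter). For compound 4 the estimate is 7000 nM, with an expected range of 1500 nM to 30000 nM.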

Compound 4, half-maximal inhibitory concentration: > 10000 nM
Compound 4: a limit, no number; the forecaster's own chance of this, stated with the estimate: 55%; at least 1.4-fold (0.15 log units) between middle value and limit.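

In this assay compound 4 gives > 10000 nM, which is a limit and not a number. With trifluoromethoxy in place of 2-oxopyrrolidin-1-yl the result is an at least 11-fold higher number from compound 3 to compound 4 (1.05 log units; beyond the scatter), so a group with the same count of hydrogen-bond donors and acceptors as the lactam does not keep the number of compound 3 at this position. The steps from compound 1 and compound 2 to compound 4 cannot be read, and compound 3 alone stands clear of the limit: the limit of > 10000 nM in this assay, at which 3 of the 4 values shown sit.

The compounds shown leave open whether the ring, the carbonyl or the ring nitrogen carries the gain, and whether an open-chain acetamide, piperidin-2-one or pyrrolidine without the carbonyl would give a number in this assay. Nor can compound 1, compound 2 and compound 4 be ordered among themselves.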